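This account rests on a few compounds, and the source may have more. Where it says the series, first, only, none or still open, it means among the compounds named here.

Measured in a functional assay on PC-3 cells (Homo sapiens) for inhibition, read by MTT assay, with a stated time of 48 h, tested at 10 uM; a higher number here means more inhibition of growth at the concentration tested, a lower number less inhibition of growth:
- compound 1 `Cc1cc(=O)c2c(O)cc(OCc3ccco3)c([C@H]3CCN(C)C[C@H]3O)c2o1`: 14%
- compound 2 `Cc1cc(=O)c2c(O)c(CN3CCCC3)c(O)c([C@H]3CCN(C)C[C@H]3O)c2o1`: 10%

Compound 2, at 10%, lies within the usual scatter of compound 1, at 14%, so the two cannot be ranked in this assay. Both values are small on this read-out, and compound 2 therefore offers little room for a further fall.

The next compound is compound 3 `Cc1cc(=O)c2c(O)c(CN(C(C)C)C(C)C)c(O)c([C@H]3CCN(C)C[C@H]3O)c2o1`. It keeps the shared core of compound 2 and carries diisopropylamino in place of pyrrolidin-1-yl on a saturated chain carbon bound to an aromatic carbon.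

For the measured compounds named here, no pair of measured compounds differing in one place is available, so the data give no direct size for this change. With only these two nearby values as a guide, no step beyond the scatter is expected in this assay. The estimated move is a number 2 percentage points higher from compound 2 to compound 3 (within the scatter), and it is expected to remain within the scatter.

For compound 3 the expected value is 12%, with an estimated range of 0% to 28%.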

Compound 3, percent growth inhibition at one concentration: 0%
Estimate against measurement, compound 3: 12 percentage points above; low and high end bracket the measured number.
By their numbers in this assay, from the lowest: compounds 3, 2 and 1 (each within the scatter of the next, the first and the last beyond it).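

In this assay, this position now has its first directly readable change, the step of a number 10 percentage points lower from compound 2 to compound 3 (within the scatter), which replaces pyrrolidin-1-yl with diisopropylamino on a saturated chain carbon bound to an aromatic carbon. Opening the five-membered non-aromatic ring and going from 5 to 7 heavy atoms therefore gives no step beyond the scatter in this single pair, although with compound 2 at 10% the read-out has little room to show a loss. No measurement is available to explain the values of these two compounds.

The compounds shown leave open whether a dimethylamino or morpholin-4-yl group on the same chain carbon would read differently from pyrrolidin-1-yl, and whether a carboxylic acid or a longer alkyl chain in place of the amine would lift the number beyond the scatter. With a single tested concentration, they also leave open whether compound 2 and compound 3 would separate at a higher concentration.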